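From Bromo to Dimethylamino: Expecting a Small Step

The source may report more compounds than this note shows. Statements on the series, on what has been measured and on what is new or still open speak of the compounds shown alone.

compound 1 `O=C1C=CCC/C1=C\C=C\c1ccccc1`: 5400 nM
compound 2 `O=C1C=CCC/C1=C\C=C\c1ccc(Br)cc1`: 5200 nM

In a functional assay on HCT-116 cells (Homo sapiens) for cytotoxicity, read by MTT assay, with a stated time of 72 h (a lower number here means a stronger inhibitor, a higher number a weaker inhibitor), compound 2 has the lower of the two numbers, yet a 1.0-fold lower number from compound 1 to compound 2 (0.02 log units; within the scatter) lies within the scatter, so the two compounds cannot be told apart. Compound 3 `CN(C)c1ccc(/C=C/C=C2\CCC=CC2=O)cc1` differs from compound 2 in one place: dimethylamino in place of bromo on an aromatic carbon. Among the compounds with values here, the only measured step, a 1.0-fold lower number from compound 1 to compound 2 (0.02 log units; within the scatter), shows that changing this same position barely moved the number. Within the data shown here, no measured step tests a dimethylamino group, so the expected step of a 1.3-fold lower number from compound 2 to compound 3 (0.11 log units; within the scatter) is small. Compound 3 is estimated at 4000 nM, within 1500 nM to 12000 nM.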

Compound 3, half-maximal inhibitory concentration: 1200 nM
For compound 3 the middle estimate is 3.3-fold (0.52 log units) above the measured one; the measured number lies below the stated range.
By their numbers in this assay, from the lowest: compound 3; then compounds 2 and 1 (each within the scatter of the next).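

In this assay, the dimethylamino group gives a 4.3-fold lower number from compound 2 to compound 3 (0.64 log units; beyond the scatter) and a 4.5-fold lower number from compound 1 to compound 3 (0.65 log units; beyond the scatter), while bromo in place of hydrogen had stayed within the scatter. This position on the aromatic ring can therefore change the number, depending on which group sits there. Nothing measured here explains this step. From the compounds shown here alone, it remains open whether a plain amino group or a methoxy group at this position would lower the number in the same way, and whether a larger amine such as morpholine would lower it further.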